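A few compounds are considered here, and "the series" means these few. Any claim that something is new, unique, unknown or untested is made for them only; others in the source may bear on it.

Measured so far:
- compound 1 `O=C(Nc1cccc(/C=C/C(=O)c2nc3ccccc3[nH]2)c1)c1cccc(Br)c1`: 1560 nM
- compound 2 `COc1ccc(C(=O)Nc2cccc(/C=C/C(=O)c3nc4ccccc4[nH]3)c2)cc1`: 4880 nM

In a functional assay on HCT-116 cells (Homo sapiens) for antiproliferative activity, read by MTT assay, with a stated time of 48 h (on this read-out lower numbers stand for stronger inhibition and higher numbers for weaker inhibition), compound 2 gives 4880 nM, the higher of the two numbers, while compound 1 gives 1560 nM. Going by the values given here, the only measured step, a 3.1-fold higher number from compound 1 to compound 2 (0.50 log units; beyond the scatter), concerns a different exchange on the carbonyl carbon and so offers no direct guide. Compound 3 `Cc1ccc(S(=O)(=O)Nc2cccc(/C=C/C(=O)c3nc4ccccc4[nH]3)c2)cc1` differs from compound 2 by (4-methylphenyl)sulfonyl in place of (4-methoxyphenyl)carbonyl on a nitrogen on an aromatic ring. Among the compounds with values here, with no measured step covering this exchange, the step of a 1.1-fold lower number from compound 2 to compound 3 (0.04 log units; within the scatter) is expected to stay within the scatter, in no clear direction. Compound 3 is therefore estimated at 4500 nM, with a range from 1500 nM to 14000 nM.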

Compound 3, half-maximal inhibitory concentration: 1990 nM
Compound 3: middle estimate off by 2.3-fold (0.35 log units), on the high side, and the stated range covers the measured number.
By their numbers in this assay, from the lowest: compounds 1 and 3 (each within the scatter of the next); then compound 2.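

In this assay, the change on the nitrogen brings a 2.5-fold lower number from compound 2 to compound 3 (0.39 log units; beyond the scatter) when (4-methylphenyl)sulfonyl replaces (4-methoxyphenyl)carbonyl, so this position accepts a sulfonyl link as well as a carbonyl. Set against (3-bromophenyl)carbonyl, the same group gives a 1.3-fold higher number from compound 1 to compound 3 (0.11 log units; within the scatter) and so shows no separation from that compound. No measured evidence here accounts for these results. As far as these compounds go, the link and the group on the phenyl ring change together, so their separate shares stay unknown. Also open, from the compounds shown here alone, is how an amine, a carboxylic acid or a longer chain on that ring would behave.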